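Branched alkyl on the ring nitrogen of the core

The compounds below may be only part of what the source reports. "The series", "measured", "known", "first", "only" and "open" are said of these compounds alone.

For the measured compounds named here, compound 2 `CCCn1c(-c2ccc(OCc3c(-c4c(Cl)cccc4Cl)noc3C(C)C)cc2)nc2ccc(C(=O)O)cc21` gives 96.4 nM in an assay on isolated protein for agonist activity at Bile acid receptor (Homo sapiens), read by TR-FRET (a higher number here means that more compound is needed for the effect, a lower number that less compound is needed), and stands as the lowest of the two numbers so far; its nearest neighbour is compound 1 `CC(C)c1onc(-c2c(Cl)cccc2Cl)c1COc1ccc(-c2nc3ccc(C(=O)O)cc3n2Cc2ccc(F)cc2)cc1` with 105 nM, a gap within the scatter. Going by the values given here, the one measured step that varies the group on the ring nitrogen, a 1.1-fold lower number from compound 1 to compound 2 (0.04 log units; within the scatter), was small. Compound 3 `CCCC(CCC)n1c(-c2ccc(OCc3c(-c4c(Cl)cccc4Cl)noc3C(C)C)cc2)nc2ccc(C(=O)O)cc21` carries the change (1-propylbutyl in place of propyl on an aromatic nitrogen), again a variation of that same substituent, though a larger one than the measured step covers. Among the compounds with values here, with only one bearing step and that one within the scatter, no shift beyond the scatter is expected for compound 3 in this assay, with the range kept wide because the enlargement is unprecedented in the pair measured so far. Compound 3 is estimated at 110 nM (range 40 nM to 320 nM), an expected step of a 1.1-fold higher number from compound 2 to compound 3 (0.06 log units; within the scatter).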

Compound 3, half-maximal effective concentration: 30.3 nM
Compound 3: the middle estimate sits 3.6-fold (0.56 log units) above what was measured; the measured number lies below the stated range.
By their numbers in this assay, from the lowest: compound 3; then compounds 2 and 1 (each within the scatter of the next).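

In this assay this position turns out not to be flat: with 1-propylbutyl on the aromatic nitrogen the series shows a 3.2-fold lower number from compound 2 to compound 3 (0.50 log units; beyond the scatter) and also a 3.5-fold lower number from compound 1 to compound 3 (0.54 log units; beyond the scatter) as modest steps beyond the scatter. Propyl and 4-fluorobenzyl had stayed within the scatter of each other, so the first movement at this nitrogen comes only with 1-propylbutyl, the largest alkyl group shown here. Nothing available explains this gain.

The compounds shown cannot separate branching from carbon count, and an unbranched heptyl chain on the same nitrogen would address that directly. As far as these compounds go, how the trend continues also remains open, both for smaller branched groups such as 1-ethylpropyl and for a ring such as cyclohexyl.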